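Swapping a Two-Ring Group for a Small Pyrazole Amine

This account rests on a few compounds, and the source may have more. Where it says the series, first, only, none or still open, it means among the compounds named here.

Of the compounds shown here, three with a shared core have been measured so far: compound 1 `Cc1nccn1-c1cnc(NCc2c(F)ccc3c2CCO3)c2cn[nH]c(=O)c12`, compound 2 `Cn1cc(-c2cnc(NCc3c(F)ccc4c3CCO4)c3cn[nH]c(=O)c23)cn1` and compound 3 `O=C1c2ccccc2CN1c1cnc(NCc2c(F)ccc3c2CCO3)n2cnnc12`. In an ADME assay on microsomes from liver (Homo sapiens) for metabolic stability, read by LC-MS, using NADPH, with stated times of 5 min and 30 min, tested at 1 uM (a lower number here means slower removal, a higher number faster removal of the compound), compound 1 gives 8 mL.min-1.g-1, compound 2 gives 21 mL.min-1.g-1 and compound 3 gives 13 mL.min-1.g-1. Compound 3 stands second highest of the three numbers, yet its gaps to compound 2 and to compound 1 both lie within the scatter, so the three cannot be placed in any firm order.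

Compound 4 `CN(c1ccn(C)n1)c1cnc(NCc2c(F)ccc3c2CCO3)n2cnnc12` differs from compound 3 in one place: a group of 8 heavy atoms (5 carbon, 3 nitrogen; one five-membered aromatic ring with 2 hetero atoms) in place of a group of 10 heavy atoms (8 carbon, 1 nitrogen, 1 oxygen; one five-membered non-aromatic ring with 1 hetero atom, one six-membered aromatic ring of carbon only), on an aromatic carbon. For the measured compounds named here, the only measured step, a 2.6-fold higher number from compound 1 to compound 2 (0.42 log units; beyond the scatter), also brought a methylpyrazole group onto an aromatic carbon and was modest. Going by the values given here, it bears on compound 4 only loosely, since the group that leaves here is larger and of a different kind, and no measured step removes such a group. A modest upward step is expected, a 1.4-fold higher number from compound 3 to compound 4 (0.14 log units; within the scatter), leaning toward the number of compound 2. Compound 4 is therefore expected to give about 18 mL.min-1.g-1, within a range from 7 mL.min-1.g-1 to 45 mL.min-1.g-1.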

Compound 4, intrinsic clearance in microsomes: 11 mL.min-1.g-1
The estimate for compound 4 lay 1.6-fold (0.21 log units) above the measured number; the range from low to high includes it.
By their numbers in this assay, from the lowest: compounds 1, 4, 3 and 2 (each within the scatter of the next, the first and the last beyond it).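

In this assay, the methyl(1-methyl-1H-pyrazol-3-yl)amino group replaces the two-ring group on this aromatic carbon with a 1.2-fold lower number from compound 3 to compound 4 (0.07 log units; within the scatter). Even an exchange of a fused two-ring group for a single five-membered aromatic ring, joined through an amine, therefore gives two numbers that cannot be told apart. This position on the shared core of compound 3 and compound 4 thus accommodates two quite different groups with no clear shift in the clearance read-out, though no measurement here bears on the reason.

From the compounds shown here alone, how a small amine such as dimethylamino, or a carboxylic acid, would read at this position stays open. Going by these compounds, it is also open whether a methylpyrazole joined directly to the ring, as in compound 2, would read the same on the core of compound 3.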